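From Methoxycarbonyl to Sulfanyl on a Shared Core

The source may report more compounds than this note shows. Statements on the series, on what has been measured and on what is new or still open speak of the compounds shown alone.

Of the compounds shown here, three built on one large shared core have been tested so far. In a functional assay on P388 cells (Mus musculus) for cytotoxicity (on this read-out lower numbers stand for stronger inhibition and higher numbers for weaker inhibition), compound 2 `COC(=O)C[C@@H]1NC(=O)[C@@H](C)NC(=O)[C@@H]2Cc3ccc(OC)c(c3)Oc3ccc(cc3)C[C@@H](C(=O)N2C)N(C)C(=O)[C@H](C)NC(=O)[C@H](Cc2ccc(OC)cc2)N(C)C1=O` gives 41.7 nM and compound 1 `COC(=O)CC[C@@H]1NC(=O)[C@@H](C)NC(=O)[C@@H]2Cc3ccc(OC)c(c3)Oc3ccc(cc3)C[C@@H](C(=O)N2C)N(C)C(=O)[C@H](C)NC(=O)[C@H](Cc2ccc(OC)cc2)N(C)C1=O` gives 58.9 nM, so these two sit together at the low end of the numbers, within the usual scatter of each other. Compound 3 `COc1ccc(C[C@H]2C(=O)N[C@@H](C)C(=O)N(C)[C@H]3Cc4ccc(cc4)Oc4cc(ccc4OC)C[C@@H](C(=O)N[C@H](C)C(=O)NC4(SCCS4)C(=O)N2C)N(C)C3=O)cc1` gives a clearly higher 631 nM.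

The next candidate is compound 4 `COc1ccc(C[C@H]2C(=O)N[C@@H](C)C(=O)N(C)[C@H]3Cc4ccc(cc4)Oc4cc(ccc4OC)C[C@@H](C(=O)N[C@H](C)C(=O)N[C@@H](CS)C(=O)N2C)N(C)C3=O)cc1`, which departs from compound 2 in a single place: sulfanyl in place of methoxycarbonyl on a saturated chain carbon bound to a saturated ring carbon. In words, sulfanyl stands in place of methoxycarbonyl on a saturated chain carbon bound to a saturated ring carbon.

Among the compounds with values here, only one measured single-change step bears on this. Going a 1.4-fold lower number from compound 1 to compound 2 (0.15 log units; within the scatter), methoxycarbonyl replaces (methoxycarbonyl)methyl at the same kind of place, and the size of that step lies within the scatter. Within the data shown here, that is thin evidence, since no measured compound yet carries sulfanyl there, so the range must stay wide. In this assay, the expected change is a 1.8-fold higher number from compound 2 to compound 4 (0.25 log units; within the scatter), which means no expected step beyond the scatter in either direction. The estimate for compound 4 is 75 nM, with an expected range from 20 nM to 350 nM.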

Compound 4, half-maximal inhibitory concentration: 363 nM
The estimate for compound 4 lay 4.8-fold (0.68 log units) below the measured number, and the stated range ends below it.
By their numbers in this assay, from the lowest: compounds 2 and 1 (each within the scatter of the next); then compounds 4 and 3 (each within the scatter of the next).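

In this assay, the earlier step between two related groups at this place, a 1.4-fold lower number from compound 1 to compound 2 (0.15 log units; within the scatter), gave no sign that the position responds to a change, but the swap to sulfanyl does move the number: an 8.7-fold higher number from compound 2 to compound 4 (0.94 log units; beyond the scatter), and a 6.2-fold higher number from compound 1 to compound 4 (0.79 log units; beyond the scatter), both beyond the scatter and both towards weaker inhibition. The position therefore tolerates a change in the length of the chain carrying methoxycarbonyl across this one pair, but it does not accept every group equally. Sulfanyl differs from methoxycarbonyl in its heavy atoms, its hydrogen-bond donors and its hydrogen-bond acceptors all at once, and nothing measured here separates these differences or explains the rise.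

The compounds shown leave open whether the rise follows from the arrival of sulfanyl or simply from the loss of methoxycarbonyl. A hydroxyl, an amine or a carboxylic acid at the same place, or sulfanyl on a longer chain, would help to tell these two readings apart.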